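Cyclobutylmethoxy to neopentyloxy on the shared core

This account rests on a few compounds, and the source may have more. Where it says the series, first, only, none or still open, it means among the compounds named here.

Among the compounds with values here, two compounds on this core have entries so far, and only one carries a number. In a physicochemical assay for solubility (a lower number here means a less soluble compound, a higher number a more soluble compound), compound 1 (`CS(=O)(=O)c1ccc(-n2nc(C(F)(F)F)cc2NCC2CC2)nc1`) is recorded as "not determined" (no result reported), so it offers no comparison. Compound 2 (`CS(=O)(=O)c1ccc(-n2nc(C(F)(F)F)cc2OCC2CCC2)nc1`) gives 100 ug/mL. With no second number, its rank within the series cannot be stated.

The next compound, compound 3 (`CC(C)(C)COc1cc(C(F)(F)F)nn1-c1ccc(S(C)(=O)=O)cn1`), differs from compound 2 in one place: tert-butyl in place of cyclobutyl on a saturated chain carbon bound to an oxygen on an aromatic ring. Cut one bond further out, the same difference reads cyclobutylmethoxy to neopentyloxy.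

Within the data shown here, no measured pair shows a change of this kind, so the expectation rests only on the structural change and on compound 2 at 100 ug/mL. In this assay no shift beyond the usual scatter is expected, with a slight lean towards a lower number. The expected change is a 1.3-fold lower number from compound 2 to compound 3 (0.10 log units; within the scatter). For compound 3 the estimated value is 80 ug/mL, with an expected range of 25 ug/mL to 200 ug/mL.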

Compound 3, solubility: 100 ug/mL
Compound 3: the middle estimate sits 1.3-fold (0.10 log units) below what was measured; the range from low to high includes it.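

In this assay the series now holds its first pair that differs in one place, and the step reads no change at the digits printed from compound 2 to compound 3 (within the scatter). On a saturated chain carbon bound to an oxygen on an aromatic ring, a swap from cyclobutyl, with its four-membered non-aromatic ring, to tert-butyl, with no ring, therefore gives no readable difference, so at this position the ring in this carbon-only group of 4 heavy atoms is not needed to keep the read-out where compound 2 has it. No supporting measurement is available to explain why the two compounds read alike.

Within the data shown here, this single step covers only two carbon-only groups of equal heavy-atom count, and compound 1 has no number, so the series offers no second reading on the shared core. Open questions are whether a longer chain in place of tert-butyl, or a morpholine or a carboxylic acid carried on the same chain carbon, would move the read-out beyond the usual scatter.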